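Aryl amide versus cyclopentylmethyl amide in the series

A few compounds are considered here, and "the series" means these few. Any claim that something is new, unique, unknown or untested is made for them only; others in the source may bear on it.

Working notes on a set of sulfonamide-linked amides sharing one core. Compound 1 `CCCC(=O)N1CCC(NS(=O)(=O)c2ccc(NC(=O)c3ccccc3)c3ccccc23)CC1` carries a phenyl on the carbonyl carbon; in an in vitro functional assay on CHO/Galpha16 cells for antagonist activity at C-C chemokine receptor type 8 (Homo sapiens), read by FLIPR (a higher number here means a weaker inhibitor, a lower number a stronger inhibitor), compound 1 gives 12.5 nM. Among the measured compounds shown here, compound 2 `CCCC(=O)N1CCC(NS(=O)(=O)c2ccc(NC(=O)CC3CCCC3)c3ccccc23)CC1` carries a cyclopentylmethyl there and in this assay compound 2 gives 145 nM, the highest of the three numbers so far. Compound 3 `CCCC(=O)N1CCC(NS(=O)(=O)c2ccc(NC(=O)c3ccc(F)cc3)c3ccccc23)CC1` carries a 4-fluorophenyl; in this assay compound 3 gives 59.5 nM.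

Compound 4 `CCCC(=O)N1CCC(NS(=O)(=O)c2ccc(NC(=O)c3ccc(CC)cc3)c3ccccc23)CC1` is not yet measured. The change from compound 2 is 4-ethylphenyl in place of cyclopentylmethyl on a carbonyl carbon. For the measured compounds named here, two measured steps bear on it: a 12-fold higher number from compound 1 to compound 2 (1.06 log units; beyond the scatter) and a 2.4-fold lower number from compound 2 to compound 3 (0.39 log units; beyond the scatter). Both show the aromatic amide giving the lower number in this assay than the cyclopentylmethyl amide, with the bare phenyl further below than the fluorinated phenyl, as a 4.8-fold higher number from compound 1 to compound 3 (0.68 log units; beyond the scatter) shows. Going by the values given here, the ethyl substituent on the phenyl has no measured counterpart, so the size of the benefit is uncertain, but a lower number is expected. The step is estimated as a 2.9-fold lower number from compound 2 to compound 4 (0.46 log units; beyond the scatter). For compound 4 in this assay the expected value is 50 nM, with a range from 15 nM to 160 nM.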

Compound 4, half-maximal inhibitory concentration: 10.8 nM
Estimate against measurement, compound 4: 4.6-fold (0.67 log units) above; measured number outside the range, below it.
By their numbers in this assay, from the lowest: compounds 4 and 1 (each within the scatter of the next); then compound 3; then compound 2.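

The 4-ethylphenyl amide sits as far from the cyclopentylmethyl amide as the bare phenyl does, with a 13-fold lower number from compound 2 to compound 4 (1.13 log units; beyond the scatter) in this assay, so a substituent on this aryl amide does not of itself cost activity. Ethyl in place of hydrogen on the aromatic carbon gives no separable change, with a 1.2-fold lower number from compound 1 to compound 4 (0.06 log units; within the scatter) and the two values remaining within the scatter of each other. Among these three aryl amides only the fluoro compound stands apart, with a 5.5-fold lower number from compound 3 to compound 4 (0.74 log units; beyond the scatter) for ethyl in place of fluoro, and nothing measured here accounts for that difference.

As far as these compounds go, whether a longer chain such as propyl or a branched tert-butyl group keeps the number as low remains open. So does the outcome with a methoxy group, a nitrile or a carboxylic acid on that aromatic carbon.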